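The source may hold more compounds than are shown below. What is called first, only, known or untested is meant among the compounds shown, and "the series" means these compounds.

Compound 1, `O=C(Nc1ncc(C(=O)O)c2nc(-c3ccco3)nn12)NC1CCCCC1`: in an assay on CHO cells for displacement of a labelled ligand from adenosine receptor A1 (Homo sapiens) (on this read-out lower numbers stand for stronger inhibition and higher numbers for weaker inhibition), compound 1 gives > 100000 nM, which is a limit of the assay and not a number.
Compound 2, `CCOC(=O)c1cnc(NCC2CCCCC2)n2nc(-c3ccco3)nc12`: in this assay compound 2 gives 432 nM.
Compound 3, `CCCCC(CC)CNc1ncc(C(=O)O)c2nc(-c3ccco3)nn12`: in this assay compound 3 gives 1780 nM.

Among the two numbers that are not limits, compound 3 stands highest in this assay, and its nearest neighbour is compound 2, whose number is lower by a margin beyond the scatter. Compound 2 and compound 3 differ in more than one place, so their values can only be set side by side. For the measured compounds named here, the one single-point step measured is an at least 56-fold lower number from compound 1 to compound 3 (1.74 log units; beyond the scatter), and it ends at the limit of compound 1 (the limit of > 100000 nM in this assay, at which 1 of the 3 values shown sits), so its true size is not fixed.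

Compound 4, `O=C(O)c1cnc(NCc2ccc(Cl)cc2)n2nc(-c3ccco3)nc12`, is not yet measured. It differs from compound 3 by 4-chlorophenyl in place of 1-ethylpentyl on a saturated chain carbon bound to a nitrogen on an aromatic ring. Going by the values given here, no measured step changes this position in a comparable way; the step from compound 1 to compound 3 only shows that the group on that nitrogen can shift the number strongly. With no closer guide, compound 4 is expected to land near compound 3, with a modest step of a 2.0-fold lower number from compound 3 to compound 4 (0.30 log units; within the scatter) in this assay towards a lower number, and wide uncertainty. Compound 4 is therefore estimated at 900 nM, between 200 nM and 4500 nM.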

Compound 4, inhibition constant: > 100000 nM
Compound 4 gave a limit, no number (the forecaster's own chance of this, stated with the estimate: 5%); middle value at least 110-fold (2.04 log units) away from the limit.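

Within this assay, replacing 1-ethylpentyl with 4-chlorophenyl on a saturated chain carbon bound to a nitrogen on an aromatic ring gives an at least 56-fold higher number from compound 3 to compound 4 (1.74 log units; beyond the scatter). The earlier step showed only that exchanging cyclohexylcarbamoyl for 2-ethylhexyl could shift the number strongly, whereas this one shows a strong shift even with the carbon chain held on the nitrogen and the heavy-atom count of the exchanged groups unchanged, so 2-ethylhexyl and 4-chlorobenzyl are not interchangeable here. Compound 4 and compound 1 both stand at a limit of the assay and not at a number, so the step between them cannot be read and the step to compound 4 has no fixed size: the limit of > 100000 nM in this assay, at which 2 of the 4 values shown sit.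

The compounds shown leave open whether the high number goes with the aromatic ring or with its chlorine, a question that a plain benzyl or a 4-methoxybenzyl group on that nitrogen would address. Also open, from the compounds shown here alone, is how the carboxylic acid and the ethyl ester compare when the group on the nitrogen is the same, as would be seen with a cyclohexylmethyl group on the carboxylic acid.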